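Chloro in Place of Hydroxy on a Saturated Ring Carbon

The source may report more compounds than this note shows. Statements on the series, on what has been measured and on what is new or still open speak of the compounds shown alone.

Compound 2 `O=C(Nc1ccc(S(=O)(=O)N2CCC(O)CC2)cc1)c1ccc([N+](=O)[O-])o1` gives 2000 nM in an assay on CHO-K1 cells for activation of DNA damage-inducible transcript 3 protein (Homo sapiens), read by a luciferase reporter (on this read-out lower numbers stand for an effect already at smaller amounts and higher numbers for an effect only at larger amounts of compound), the highest of the three numbers shown, although its gap to compound 1 lies within the scatter. Compound 1 `CC1CN(S(=O)(=O)c2ccc(NC(=O)c3ccc([N+](=O)[O-])o3)cc2)CC(C)O1` gives 1400 nM, a step of a 1.4-fold higher number from compound 1 to compound 2 (0.15 log units; within the scatter). Compound 3 `O=C(Nc1ccc(S(=O)(=O)N2CCC(F)CC2)cc1)c1ccc([N+](=O)[O-])o1` gives 600 nM, so that a 3.3-fold lower number from compound 2 to compound 3 (0.52 log units; beyond the scatter) and a 2.3-fold lower number from compound 1 to compound 3 (0.37 log units; beyond the scatter). Compound 4 `O=C(Nc1ccc(S(=O)(=O)N2CCC(Cl)CC2)cc1)c1ccc([N+](=O)[O-])o1` differs from compound 2 by chloro in place of hydroxy on a saturated ring carbon. The step that bears on it is the exchange of the same hydroxy for a halogen on the same saturated ring carbon, where the number fell modestly. Because a 3.3-fold lower number from compound 2 to compound 3 (0.52 log units; beyond the scatter) was modest, a drop of similar size is expected here, a 2.9-fold lower number from compound 2 to compound 4 (0.46 log units; beyond the scatter). Compound 4 is therefore estimated at 700 nM, with a range from 300 nM to 1600 nM.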

Compound 4, concentration for half-maximal activity: 800 nM
Compound 4: the middle estimate sits 1.1-fold (0.06 log units) below what was measured; low and high end bracket the measured number.
By their numbers in this assay, from the lowest: compounds 3, 4, 1 and 2 (each within the scatter of the next, the first and the last beyond it).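

In this assay, chloro on this saturated ring carbon also gives a lower number than hydroxy (a 2.5-fold lower number from compound 2 to compound 4 (0.40 log units; beyond the scatter)), so the drop seen with fluoro now holds for a second halogen. The two halogens cannot be told apart here (a 1.3-fold higher number from compound 3 to compound 4 (0.12 log units; within the scatter)), and 4-chloropiperidin-1-yl likewise stays level with 2,6-dimethylmorpholin-4-yl (a 1.8-fold lower number from compound 1 to compound 4 (0.24 log units; within the scatter)). No measurement on hand accounts for these results.

As far as these compounds go, whether an amine, a methoxy group or a nitrile on the same carbon would match the halogens remains open. So does whether the plain piperidin-1-yl group would sit nearer the halogens or hydroxy.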